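Two inactive spiro compounds and a trichlorophenyl analogue

The compounds below may be only part of what the source reports. "The series", "measured", "known", "first", "only" and "open" are said of these compounds alone.

Compound 1 `N#CC1=C(N)Oc2c(c3nc4ccccc4nc3c3ccccc23)C12C(=O)N(Cc1cnnn1-c1cc(Cl)ccc1Cl)c1ccccc12`: > 50000 nM
Compound 2 `CCOc1ccccc1-n1nncc1CN1C(=O)C2(C(C#N)=C(N)Oc3c(N)cc4nc5ccccc5nc4c32)c2ccccc21`: > 50000 nM

Both measured compounds share a spiro core and differ in the aryl group on the triazole nitrogen and in the substitution of the fused ring system. In a functional assay on HCT-116 cells (Homo sapiens) for antiproliferative activity, read by MTT assay, with a stated time of 48 h (a lower number here means a stronger inhibitor, a higher number a weaker inhibitor), compound 1 gives only a limit of the assay, > 50000 nM. In this assay compound 2 likewise gives only a limit, > 50000 nM. Compound 2 therefore stands at the limit (the limit of > 50000 nM in this assay, at which 2 of the 2 values shown sit), with no number of its own, and nothing separates it from compound 1 on the values shown.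

Compound 3 `N#CC1=C(N)Oc2c(N)cc3nc4ccccc4nc3c2C12C(=O)N(Cc1cnnn1-c1c(Cl)cc(Cl)cc1Cl)c1ccccc12` has not yet been measured. It differs from compound 2 in one place: 2,4,6-trichlorophenyl in place of 2-ethoxyphenyl on an aromatic nitrogen. The trichlorophenyl group recalls the dichlorophenyl of compound 1, which also returned only a limit.

For the measured compounds named here, with both measured compounds at the limit of this assay, no measured step is available, and the step from compound 2 to compound 3 is expected to be none beyond the scatter, so that the estimated value is a step that the limit leaves unreadable from compound 2 to compound 3. Compound 3 is therefore expected to come out near 60000 nM, between 20000 nM and 200000 nM, most probably again as a limit rather than a number.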

Compound 3, half-maximal inhibitory concentration: 12100 nM
The estimate for compound 3 lay 5.0-fold (0.70 log units) above the measured number; the measured number lies below the stated range.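

In this assay, for the compounds shown here, 2,4,6-trichlorophenyl in place of 2-ethoxyphenyl on an aromatic nitrogen of a five-membered aromatic ring with 3 nitrogen gives an at least 4.1-fold lower number from compound 2 to compound 3 (0.61 log units; beyond the scatter), the first readable step, and it shows that the group at this position can bring the shared core off the limit. The two groups have the same heavy-atom count and each holds one six-membered aromatic ring of carbon only, so the step goes with a change in what that ring carries, the ethoxy group giving way to three chlorine atoms, and compound 3 gives a number of its own, 12100 nM. The true size of the step stays unknown because compound 2 has only a limit and no number of its own: the limit of > 50000 nM in this assay, at which 2 of the 3 values shown sit.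

From the compounds shown here alone, it remains open whether all three chlorine atoms are needed, or whether a plain phenyl or a monochlorophenyl at this position would also give a number. Also open, going by these compounds, is whether the core of compound 3 would keep its value without its amine.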